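Shifting one methoxy group on a growth inhibitor

A few compounds are considered here, and "the series" means these few. Any claim that something is new, unique, unknown or untested is made for them only; others in the source may bear on it.

Compound 1 `COc1cc(/C=C/C(=O)/C=C/c2cccc3ccccc23)ccc1OCc1cn(CCCCCOc2cc(=O)oc3ccccc23)nn1` gives 44%
Compound 2 `COc1cccc(/C=C/C(=O)/C=C/c2ccc(OCc3cn(CCOc4cc(=O)oc5ccccc45)nn3)c(OC)c2)c1` gives 77%

Both numbers come from a functional assay on THP-1 cells (Homo sapiens) for inhibition, read by sulforhodamine B assay, with a stated time of 48 h, tested at 50 uM (on this read-out lower numbers stand for less inhibition of growth and higher numbers for more inhibition of growth at the one concentration tested), and compound 2 holds the higher of the two, with a gap to compound 1 that lies beyond the usual scatter. These two compounds differ in more than one place, so their gap says little about any single change. Next comes compound 3 `COc1ccccc1/C=C/C(=O)/C=C/c1ccc(OCc2cn(CCOc3cc(=O)oc4ccccc34)nn2)c(OC)c1` which has the same atoms as compound 2, joined differently. The change is 2-methoxyphenyl in place of 3-methoxyphenyl on a double-bonded chain carbon bound to a double-bonded chain carbon and it puts 2-methoxyphenyl in place of 3-methoxyphenyl on a double-bonded chain carbon bound to a double-bonded chain carbon. Among the compounds with values here, no measured pair shows what such a shift does, so only a modest step is expected in this assay here. A slight fall seems likelier than a rise because compound 2 stands at 77% as the higher of just two values, though the change may well stay within the scatter. The estimated step is a number 7 percentage points lower from compound 2 to compound 3 (within the scatter) and it is small. For compound 3 the estimated value is 70% with an expected range from 50% to 88% around it.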

Compound 3, percent growth inhibition at one concentration: 75%
For compound 3 the middle estimate is 5 percentage points below the measured one, within the range that was stated.
By their numbers in this assay, from the lowest: compound 1; then compounds 3 and 2 (each within the scatter of the next).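

Replacing 3-methoxyphenyl with 2-methoxyphenyl on a double-bonded chain carbon bound to a double-bonded chain carbon gives a number 2 percentage points lower from compound 2 to compound 3 (within the scatter) in this assay at this site. Within the data shown here, this is the first comparison that isolates a single change, and at the one concentration tested, the read-out does not separate these two arrangements of the methoxyphenyl group. Nothing at hand explains this result, and no measured property of either group bears on it.

The pair does not show what an unsubstituted phenyl ring would do here, or how the read-out would respond to a different group on this ring, such as an amine or a carboxylic acid. Among these compounds, whether compound 2 and compound 3 would also match across a range of concentrations remains open, as does whether this shift would change so little in a compound with a longer chain, such as the one carried by compound 1.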